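Swapping one pyridine for another on the ether oxygen

The source may hold more compounds than are shown below. What is called first, only, known or untested is meant among the compounds shown, and "the series" means these compounds.

Three compounds share a core that carries a carboxylic acid and, on an oxygen on an aromatic ring, a substituted pyridine. Compound 1 `Cc1cccc(Oc2ccc3nc(COc4cccc(C(=O)O)c4)n(C)c3c2)n1` gives 0.8 in a physicochemical assay for lipophilicity, read by LC-MS, in phosphate buffer, measured as octanol-water partition, with a stated time of 30 min, at pH 7.4, tested at 200 mM; on this read-out higher numbers stand for higher lipophilicity and lower numbers for lower lipophilicity. Compound 2 `Cn1c(COc2cccc(C(=O)O)c2)nc2ccc(Oc3ccc(F)cn3)cc21` gives 0.6 in this assay, and compound 3 `Cc1cnc(Oc2ccc3nc(COc4cccc(C(=O)O)c4)n(C)c3c2)c(F)c1` gives 1.1. Compound 3 lies above compound 2, as the step of a number 0.50 log units higher from compound 2 to compound 3 (beyond the scatter) shows, while compound 1 and compound 3 sit within the scatter of each other, seen in a number 0.30 log units higher from compound 1 to compound 3 (within the scatter); the step of a number 0.20 log units lower from compound 1 to compound 2 (within the scatter) is also within the scatter.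

Compound 4 `Cc1cc(Cl)cnc1Oc1ccc2nc(COc3cccc(C(=O)O)c3)n(C)c2c1` differs from compound 3 in one place: 5-chloro-3-methylpyridin-2-yl in place of 3-fluoro-5-methylpyridin-2-yl on an oxygen on an aromatic ring. All three measured steps concern the same kind of swap of one pyridine for another on this oxygen, and the widest of them, from compound 2 to compound 3, was only modest. A change of similar or smaller size is therefore expected here, in the upward direction, as a number 0.40 log units higher from compound 3 to compound 4 (beyond the scatter) expresses. Compound 4 is accordingly estimated at 1.5 in this assay, with a range from 1 to 2.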

Compound 4, distribution coefficient: 1.8
For compound 4 the middle estimate is 0.30 log units below the measured one; measured number inside the range.
By their numbers in this assay, from the lowest: compounds 2, 1 and 3 (each within the scatter of the next, the first and the last beyond it); then compound 4.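

Going by these compounds alone, this position proved more responsive than the earlier compounds suggested: the first measured step beyond the scatter that starts from compound 3 is upward and sizeable (a number 0.70 log units higher from compound 3 to compound 4 (beyond the scatter)), and compound 4 also stands clear of the other two (a number 1.00 log units higher from compound 1 to compound 4 (beyond the scatter); a number 1.20 log units higher from compound 2 to compound 4 (beyond the scatter)), so it has the highest number of the four in this assay. Within the data shown here, the largest of these steps is large, whereas no step among the first three compounds went beyond modest, so the choice of pyridine on this oxygen can move the read-out much further than those compounds showed, even though the groups leaving and entering in the step from compound 3 have the same count of heavy atoms, donors and acceptors. Nothing available here accounts for the size of this rise.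

The names 3-fluoro-5-methylpyridin-2-yl and 5-chloro-3-methylpyridin-2-yl differ both in the halogen and in the placing of the methyl, and the compounds shown do not separate these two changes. As far as these compounds go, it also remains open how this read-out would respond to a 5-bromo-3-methylpyridin-2-yl group, or to a pyridine carrying an amine.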